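The compounds below may be only part of what the source reports. "The series", "measured", "known", "first", "only" and "open" are said of these compounds alone.

The measured compounds and their values in an assay on THP-1 cells for displacement of a labelled ligand from C-C chemokine receptor type 1 (Homo sapiens); on this read-out lower numbers stand for stronger inhibition and higher numbers for weaker inhibition:

compound 1, `CC(C)CCC(=O)N[C@@H](C(=O)N1CCC(c2ccc(Cl)cc2)CC1)C(C)C`: 26 nM
compound 2, `CC(C)C(NC(=O)c1ccccc1)C(=O)N1CCC(c2ccc(F)cc2)CC1`: 423 nM
compound 3, `Cc1ccccc1C(=O)N[C@@H](C(=O)N1CCC(c2ccc(Cl)cc2)CC1)C(C)C`: 32 nM

Compound 3 stands second highest of the three numbers in this assay. Its nearest neighbour is compound 1, with a gap of a 1.2-fold higher number from compound 1 to compound 3 (0.09 log units; within the scatter), a step that lies within the scatter, so the two cannot be ordered. Among the compounds with values here, compound 2, which differs from compound 3 in more than one place, gives a higher number than compound 3; no single step connects it to compound 3, so only the two values themselves can be compared.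

Compound 4, `CC(C)[C@@H](NC(=O)NCc1ccccc1)C(=O)N1CCC(c2ccc(Cl)cc2)CC1`, differs from compound 3 by benzylamino in place of 2-methylphenyl on a carbonyl carbon. Within the data shown here, the only measured step at that carbonyl carbon, from compound 1 to compound 3, swapped isopentyl for 2-methylphenyl and moved the number by a 1.2-fold higher number from compound 1 to compound 3 (0.09 log units; within the scatter), within the scatter. Among the measured compounds shown here, that step shows the carbonyl substituent tolerating a change from chain to aromatic ring, but no measured compound carries a benzylamino there, so the added hydrogen-bond donor is untested. A small step, most likely toward a somewhat higher number, is therefore expected for a 1.9-fold higher number from compound 3 to compound 4 (0.27 log units; within the scatter). Compound 4 is estimated at 60 nM, with a range from 20 nM to 200 nM.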

Compound 4, half-maximal inhibitory concentration: 180 nM
Compound 4: middle estimate off by 3.0-fold (0.48 log units), on the low side, within the range that was stated.
By their numbers in this assay, from the lowest: compounds 1 and 3 (each within the scatter of the next); then compound 4; then compound 2.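

In this assay, within the data shown here, the carbonyl carbon turns out to be less forgiving than the earlier compounds suggested: benzylamino in place of 2-methylphenyl gives a 5.6-fold higher number from compound 3 to compound 4 (0.75 log units; beyond the scatter), and benzylamino in place of isopentyl gives a 6.9-fold higher number from compound 1 to compound 4 (0.84 log units; beyond the scatter), both beyond the scatter. Isopentyl and 2-methylphenyl could not be told apart at this position (a 1.2-fold higher number from compound 1 to compound 3 (0.09 log units; within the scatter)), so the tolerance seen there does not extend to every group placed on this carbonyl carbon, and benzylamino is the first of the three groups to separate from the others. Nothing available bears on the reason for this rise.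

Which part of the change carries the step stays open, since benzylamino brings in a nitrogen with its hydrogen-bond donor and also places the ring differently, and the compounds shown do not separate these; a 2-phenylethyl group or a phenylamino group on the same carbonyl carbon would begin to do so. Also open, from the compounds shown here alone, is how the number would respond to an amine or a carboxylic acid on the ring of the benzylamino group, or to a longer chain in place of isopentyl.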